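Working notes: hydroxy removed, cytotoxicity to be measured

The source may hold more compounds than are shown below. What is called first, only, known or untested is meant among the compounds shown, and "the series" means these compounds.

Compound 1 `COc1cc(OC)cc(-c2cn(-c3ccc(OC)cc3OC)nn2)c1`: > 10000 nM
Compound 2 `COc1ccc(-n2cc(-c3cc(O)cc(O)c3)nn2)cc1O`: > 10000 nM
Compound 3 `COc1cc(-c2cn(-c3ccc(Oc4ccccc4)cc3)nn2)cc(OC)c1OC`: 10000 nM

In a functional assay on MDA-MB-231 cells (Homo sapiens) for cytotoxicity, read by MTT assay (a lower number here means a stronger inhibitor, a higher number a weaker inhibitor), compound 1 gives > 10000 nM, which is a limit of the assay and not a number. Compound 2 gives > 10000 nM, likewise a limit. Compound 3 gives 10000 nM. For the measured compounds named here, compound 2 therefore stands at the limit of > 10000 nM in this assay, at which 2 of the 3 values shown sit; no step between measured compounds that differ in one place is available.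

Compound 4 `COc1ccc(-n2cc(-c3cc(O)cc(O)c3)nn2)cc1` is not yet measured. It differs from compound 2 by hydrogen in place of hydroxy on an aromatic carbon. Going by the values given here, nothing among the measured compounds bears on this change, so no move beyond the scatter is expected. Compound 4 is expected near 15000 nM, between 5000 nM and 50000 nM, most likely reported again as a limit. The expected step is a step that the limit leaves unreadable from compound 2 to compound 4, none beyond the scatter.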

Compound 4, half-maximal inhibitory concentration: > 10000 nM
Compound 4: a limit, no number (the forecaster's own chance of this, stated with the estimate: 70%); the middle value does not contradict the limit.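

No step can be read between compound 2 and compound 4, because both stand at a limit and not a number: the limit of > 10000 nM in this assay, at which 3 of the 4 values shown sit.

Whether hydrogen in place of hydroxy changes cytotoxicity at all remains open in the compounds shown.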